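The source may report more compounds than this note shows. Statements on the series, on what has been measured and on what is new or still open speak of the compounds shown alone.

Measured so far:
- compound 1 `O=C(Nc1cc(Sc2ncn[nH]2)c(O)c2ccccc12)c1ccc2ccccc2c1` — in a functional assay on HCT-116 cells (Homo sapiens) for antiproliferative activity, read by MTT assay, with a stated time of 48 h (on this read-out higher numbers stand for weaker inhibition and lower numbers for stronger inhibition), compound 1 gives > 100000 nM, which is a limit of the assay, not a number.
- compound 2 `COc1ccc(C(=O)Nc2cc(Sc3ncn[nH]3)c(O)c3ccccc23)cc1` — in this assay compound 2 gives > 100000 nM, again a limit.
- compound 3 `O=C(Nc1cc(Sc2ncn[nH]2)c(O)c2ccccc12)c1ccc(Cl)cc1` — in this assay compound 3 gives 43300 nM.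

Compound 3 is thus the only one of the three with a true number; the other two sit at the limit of > 100000 nM in this assay, at which 2 of the 3 values shown sit. The step of an at least 2.3-fold lower number from compound 1 to compound 3 (0.36 log units; beyond the scatter) and the step of an at least 2.3-fold lower number from compound 2 to compound 3 (0.36 log units; beyond the scatter) both run toward compound 3, while the step that the two limits leave unreadable from compound 1 to compound 2 cannot be read, since both ends are limits.

Compound 4 `Cc1cccc(C(=O)Nc2cc(Sc3ncn[nH]3)c(O)c3ccccc23)c1` differs from compound 3 in one place: 3-methylphenyl in place of 4-chlorophenyl on a carbonyl carbon. Going by the values given here, the steps that bear on this are those that changed the same aryl group, an at least 2.3-fold lower number from compound 2 to compound 3 (0.36 log units; beyond the scatter) and an at least 2.3-fold lower number from compound 1 to compound 3 (0.36 log units; beyond the scatter), each at least modest, and each showing that only 4-chlorophenyl so far gave a measurable number. A 3-methylphenyl group is a further change of the same kind, so a step back toward weaker inhibition is expected: a 1.8-fold higher number from compound 3 to compound 4 (0.27 log units; within the scatter). Compound 4 is therefore estimated at 80000 nM, with a range from 30000 nM to 250000 nM.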

Compound 4, half-maximal inhibitory concentration: > 100000 nM
Compound 4: no number, only a limit; the forecaster's own chance of this, stated with the estimate: 45%; middle value at least 1.2-fold (0.09 log units) from the limit.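

In this assay compound 4 gives > 100000 nM as a limit of the assay, not a number. Putting 3-methylphenyl in place of 4-chlorophenyl on the carbonyl carbon therefore gives an at least 2.3-fold higher number from compound 3 to compound 4 (0.36 log units; beyond the scatter) and loses the only measurable value, so among the four compounds shown a number appears only with 4-chlorophenyl, while naphthalen-2-yl, 4-methoxyphenyl and 3-methylphenyl all end at the same ceiling: the limit of > 100000 nM in this assay, at which 3 of the 4 values shown sit. The steps among compounds 1, 2 and 4 cannot be read, since both ends of each are limits.

This change swaps the substituent and its place on the ring together, so the compounds shown leave open which of the two matters; 4-methylphenyl and 3-chlorophenyl would separate them. Also open, as far as these compounds go, is how this carbonyl position would respond to a group without an aromatic ring, such as cyclohexyl, or to an aryl group carrying an amine or a carboxylic acid.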